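Working notes: the step from compound 3 to compound 4

This account rests on a few compounds, and the source may have more. Where it says the series, first, only, none or still open, it means among the compounds named here.

Measured in a functional assay on DU-145 cells (Homo sapiens) for antiproliferative activity, read by MTT assay, with a stated time of 48 h (a lower number here means a stronger inhibitor, a higher number a weaker inhibitor), each entry a limit of the assay and not a number:
- compound 1 `C/C(=C\CC/C(C)=C/CC[C@@H]1[C@@]2(C)CCC(=O)C(C)(C)[C@H]2CC[C@@]1(C)O)CC/C=C(\C)C(=O)OCc1cn(-c2ccc(F)c(Cl)c2)nn1` gives > 150000 nM
- compound 2 `C/C(=C\CC/C(C)=C/CC[C@@H]1[C@@]2(C)CCC(=O)C(C)(C)[C@H]2CC[C@@]1(C)O)CC/C=C(\C)C(=O)OCc1cn(-c2cccc([N+](=O)[O-])c2)nn1` gives > 150000 nM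
- compound 3 `C/C(=C\CC/C(C)=C/CC[C@@H]1[C@@]2(C)CCC(=O)C(C)(C)[C@H]2CC[C@@]1(C)O)CC/C=C(\C)C(=O)OCc1cn(-c2ccccc2C)nn1` gives > 150000 nM

Compound 3 has no number of its own, only a limit, and it shares that position with the other two compounds, as the limit of > 150000 nM in this assay, at which 3 of the 3 values shown sit, shows.

The next compound, compound 4 `C/C(=C\CC/C(C)=C/CC[C@@H]1[C@@]2(C)CCC(=O)C(C)(C)[C@H]2CC[C@@]1(C)O)CC/C=C(\C)C(=O)OCc1cn(-c2cccc(Br)c2)nn1`, carries 3-bromophenyl in place of 2-methylphenyl on an aromatic nitrogen.

Among the compounds with values here, three measured steps bear on this change, since each exchanges the same aryl group: a step that the two limits leave unreadable from compound 1 to compound 2, a step that the two limits leave unreadable from compound 1 to compound 3 and a step that the two limits leave unreadable from compound 2 to compound 3. None of them has a readable size, and none gives a direction. All three aryl groups measured so far leave the compound on the same limit, which is the limit of > 150000 nM in this assay, at which 3 of the 3 values shown sit. For compound 4, no step beyond the scatter is therefore expected in this assay, in either direction, and a report of the limit alone is the likeliest outcome.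

The expected change is a number no higher from compound 3 to compound 4 (the limit leaves the size open) in size.

For compound 4 the estimated value is 150000 nM, with an expected range from 70000 nM to 300000 nM in this reading.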

Compound 4, half-maximal inhibitory concentration: > 150000 nM
Compound 4 was reported as a limit; the forecaster's own chance of this, stated with the estimate: 85%; the middle value lies on the limit itself.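

Compound 4 also gives only a limit of the assay in this assay, so no step from compound 1, compound 2 or compound 3 to compound 4 can be read: the limit of > 150000 nM in this assay, at which 4 of the 4 values shown sit.

The compounds shown leave open whether any aryl group on the shared core gives a measurable value in this assay, and how these four compounds compare with one another.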